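The source may hold more compounds than are shown below. What is called first, only, known or untested is meant among the compounds shown, and "the series" means these compounds.

Two compounds of this series have a measured value for a physicochemical assay for lipophilicity; on this read-out lower numbers stand for lower lipophilicity and higher numbers for higher lipophilicity. Compound 1, with the structure `CN(C)c1ccc(C(=O)OCC2(CO)C/C(=C\c3cnc4ccccc4c3)C(=O)O2)cc1`, gives 3.22 in this assay. Compound 2, with the structure `CN(C)c1ccc(C(=O)OCC2(CO)C/C(=C/c3ccncc3)C(=O)O2)cc1`, gives 2.07 in this assay; of these two numbers, compound 2 holds the lower one, and compound 1 stands higher by a gap wider than the usual scatter. Going by the values given here, no step between measured compounds that differ in a single place has been recorded here. Compound 3, with the structure `CN(C)c1ccc(C(=O)OCC2(CO)C/C(=C\c3ccncc3)C(=O)O2)cc1`, is the next compound to be measured in this assay. Its difference from compound 2 is the two compounds have the same atoms and bonds; at least one stereo element is drawn with a configuration in one of them and without one in the other: 1 of 2 stereo elements differ; a double bond is drawn Z in compound 2 and E in compound 3. Starting from compound 2 at 2.07, with the same atoms and bonds present and only the drawn geometry of one double bond changing, no step beyond the scatter is expected. The estimated step is a number 0.03 log units higher from compound 2 to compound 3 (within the scatter). Compound 3 is expected to give about 2.1 in this assay, within a range from 1.8 to 2.4.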

Compound 3, partition coefficient: 2.07
Estimate against measurement, compound 3: 0.03 log units above, within the range that was stated.
By their numbers in this assay, from the lowest: compounds 2 and 3 (each within the scatter of the next); then compound 1.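

In this assay, changing the drawn geometry of the double bond gives no change at the digits printed from compound 2 to compound 3 (within the scatter), so for the pyridin-4-yl pair this change leaves the number where it was. Going by these compounds alone, the group on the chain, by contrast, matters: the first comparison in which only that group differs, pyridin-4-yl in place of quinolin-3-yl, gives a number 1.15 log units lower from compound 1 to compound 3 (beyond the scatter). The geometry result carries one caution: the fact that one of compounds 2 and 3 is drawn with a defined configuration and the other without, at the place where they differ

From the compounds shown here alone, whether geometry counts for as little with quinolin-3-yl remains open, as that group appears here in a single drawn form. Also open, going by these compounds, is where a plain phenyl ring would fall in this assay at this place, which would help show whether the size of the group or the ring nitrogen goes with the step.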